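Benzyl Ring Changes on a Shared Core in HOS Cells

This account rests on a few compounds, and the source may have more. Where it says the series, first, only, none or still open, it means among the compounds named here.

Measured so far:
- compound 1, `OC[C@H]1O[C@@H](n2cnc3c(NCc4ccccc4F)ncnc32)[C@H](O)[C@@H]1O`: in a functional assay on HOS cells (Homo sapiens) for antiproliferative activity, with a stated time of 72 h (a higher number here means a weaker inhibitor, a lower number a stronger inhibitor), compound 1 gives only a limit, > 166000 nM.
- compound 2, `Cc1ccc(CNc2ncnc3c2ncn3[C@@H]2O[C@H](CO)[C@@H](O)[C@H]2O)cc1`: compound 2 likewise reaches only the limit > 166000 nM.
- compound 3, `OC[C@H]1O[C@@H](n2cnc3c(NCc4ccc(Cl)c(Cl)c4)ncnc32)[C@H](O)[C@@H]1O`: compound 3 also sits at the limit > 166000 nM.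

All three compounds share the same core and differ only in the aromatic ring on the saturated chain carbon bound to a nitrogen on an aromatic ring. Compound 1 stands at a limit and not at a number, and the other two do the same, so (the limit of > 166000 nM in this assay, at which 3 of the 3 values shown sit). The steps a step that the two limits leave unreadable from compound 1 to compound 2, a step that the two limits leave unreadable from compound 1 to compound 3 and a step that the two limits leave unreadable from compound 2 to compound 3 are therefore not readable in size or direction.

Compound 4, `COc1cccc(CNc2ncnc3c2ncn3[C@@H]2O[C@H](CO)[C@@H](O)[C@H]2O)c1O`, alters compound 1 as follows: 2-hydroxy-3-methoxyphenyl in place of 2-fluorophenyl on a saturated chain carbon bound to a nitrogen on an aromatic ring. Every measured step is hidden behind the limit, so none of them gives a direction or a size to carry over. The expectation for compound 4 is that this assay again returns a limit, estimated at 166000 nM with a range from 50000 nM to 500000 nM. The expected step of a number no higher from compound 1 to compound 4 (the limit leaves the size open) thus amounts to no change beyond the scatter.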

Compound 4, half-maximal inhibitory concentration: > 166000 nM
Compound 4: only a limit was reported; the forecaster's own chance of this, stated with the estimate: 85%; the middle value sits exactly at the limit.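

Compound 4, like compound 1, compound 2 and compound 3, gives only a limit, so its steps to those three cannot be read in size or direction: the limit of > 166000 nM in this assay, at which 4 of the 4 values shown sit.

From the compounds shown here alone, whether any ring on the shared core gives an actual number in this assay stays open, and so does how these four rings rank.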